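Swapping the dichlorophenyl arm of compound 2 for ethylphenyl

This account rests on a few compounds, and the source may have more. Where it says the series, first, only, none or still open, it means among the compounds named here.

Three related compounds have been tested in an assay for inhibition of protein disulfide-isomerase (Homo sapiens), with a stated time of 1 h; a higher number here means a weaker inhibitor, a lower number a stronger inhibitor. Compound 1 `Oc1c(C(c2ccc(F)cc2)N2CCCCC2)ccc2scnc12` gives 570 nM. Compound 3 `Oc1ccc2[nH]ncc2c1C(c1ccc(-n2cccc2)cc1)N1CCCCC1` gives 290 nM. Compound 2 `Oc1c(C(Nc2ccccn2)c2c(Cl)cccc2Cl)ccc2cccnc12` gives 1890 nM, the highest of the three numbers, so within this small set it is the weakest inhibitor; its gap to compound 1 and its gap to compound 3 both lie beyond the usual scatter of repeated measurements.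

Compound 4 `CCc1ccc(C(Nc2ccccn2)c2ccc3cccnc3c2O)cc1` has not yet been measured. It differs from compound 2 in one place: 4-ethylphenyl in place of 2,6-dichlorophenyl on a saturated chain carbon bound to an aromatic carbon and a nitrogen on an aromatic ring. Among the measured compounds shown here, compounds 1 and 3 each carry a phenyl ring bearing a single substituent, and both show lower numbers than compound 2, but they also differ from compound 2 in other parts of the molecule, so no measured pair isolates the effect of changing this aryl group alone.

With that caveat, the expected step in this assay is a modest move toward a lower number, a 1.6-fold lower number from compound 2 to compound 4 (0.20 log units; within the scatter), although an outcome within the scatter would not be surprising. Compound 4 is therefore expected to give about 1200 nM, with a plausible range from 400 nM to 3500 nM.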

Compound 4, half-maximal inhibitory concentration: 170 nM
Beside the measured number, compound 4's estimate is 7.1-fold (0.85 log units) above it; measured number outside the range, below it.
By their numbers in this assay, from the lowest: compounds 4, 3 and 1 (each within the scatter of the next, the first and the last beyond it); then compound 2.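

In this assay, among the compounds shown here, putting 4-ethylphenyl in place of 2,6-dichlorophenyl gives an 11-fold lower number from compound 2 to compound 4 (1.05 log units; beyond the scatter), and this is the first pair here that isolates a single change. For the compounds shown here, compounds 1 and 3 differ from compound 2 in other parts of the molecule as well, so only this pair shows that the aryl group on this saturated chain carbon can, on its own, shift the inhibition by a large margin beyond the scatter. The two groups match in heavy-atom count, in having one six-membered aromatic ring of carbon only, and in having no hydrogen-bond donors or acceptors, and no measurement shown explains a step of this size.

This single swap removes two chlorines, adds an ethyl group and changes where the ring is substituted, so the compounds shown cannot separate these three changes; a plain phenyl, 2,6-diethylphenyl or 4-chlorophenyl group at this place would help to pull them apart. From the compounds shown here alone, it also remains open whether the same swap would have a similar effect on the different cores of compounds 1 and 3, which carry a piperidine ring instead of the aminopyridine.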